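The compounds below may be only part of what the source reports. "The series", "measured", "known", "first", "only" and "open" are said of these compounds alone.

Measured so far:
compound 1 `CCCNC(=O)NS(=O)(=O)N1CCC(CCNC(=O)c2cc(Cl)ccc2OC)CC1`: 24%
compound 2 `O=C(NC[C@@H]1C[C@@H]2C=C[C@@H]1C2)NS(=O)(=O)N1CCC(CCNC(=O)c2cc(Cl)ccn2)CC1`: 16%

In a functional assay on the whole organism (blood) with Rattus norvegicus as the target, with stated times of 24 h and 1 h, at a dose of 1 mg/kg by the intraperitoneal route (a lower number here means a weaker effect, a higher number a stronger effect of the compound at the dose given), compound 2 gives 16%. Compound 1 gives 24%, and the gap between the two lies within the usual scatter, so compound 2 is not set apart from compound 1 on these numbers. Compound 3 `O=C(NC[C@@H]1C[C@@H]2C=C[C@@H]1C2)NS(=O)(=O)N1CCC(CCNC(=O)c2nc3ccccc3s2)CC1` is not yet measured. Its difference from compound 2: 1,3-benzothiazol-2-yl in place of 4-chloropyridin-2-yl on a carbonyl carbon. Among the measured compounds shown here, no step between measured compounds shows what this change does, so no shift beyond the scatter is expected in this assay in either direction. For compound 3 the expected value is 20%, with a range from 5% to 40%. This means an expected step of a number 4 percentage points higher from compound 2 to compound 3 (within the scatter) that stays within the scatter.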

Compound 3, a percentage reported as activity, at one dose (the size of the read-out at that dose, not a potency): 14%
The estimate for compound 3 lay 6 percentage points above the measured number, within the range that was stated.
By their numbers in this assay, from the lowest: compounds 3, 2 and 1 (each within the scatter of the next).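

Replacing 4-chloropyridin-2-yl with 1,3-benzothiazol-2-yl on a carbonyl carbon in this assay gives a number 2 percentage points lower from compound 2 to compound 3 (within the scatter). This first step at this position shows that a group of 9 heavy atoms, with a five-membered aromatic ring holding sulfur, gives a read-out not separable from that of the 7-atom pyridine group. No measurement available here accounts for this result. Still open, as far as these compounds go, is whether a carboxylic acid or a simple amine on this carbonyl would move the read-out beyond the scatter.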